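Nitro-to-amino swap on two benzimidazole series, cytotoxicity

The source may report more compounds than this note shows. Statements on the series, on what has been measured and on what is new or still open speak of the compounds shown alone.

Measured compounds:
compound 1, `Nc1ccc(-c2nc3cc(Cl)c(Cl)cc3[nH]2)cc1`, 17000 nM
compound 2, `O=[N+]([O-])c1ccc(-c2nc3cc(Cl)c(Cl)cc3[nH]2)cc1`, 17000 nM
compound 3, `COc1ccc(-c2nc3cc(C(F)(F)F)ccc3[nH]2)c([N+](=O)[O-])c1`, 85000 nM

In an ADME assay on MT4 cells (Homo sapiens) for cytotoxicity, read by MTT assay, with a stated time of 96 h (a higher number here means that more compound is tolerated, a lower number that less compound is tolerated), compound 2 gives 17000 nM and compound 1 gives 17000 nM. The step between them, no change at the digits printed from compound 2 to compound 1 (within the scatter), comes with the change (amino in place of nitro on an aromatic carbon). Compound 3 gives 85000 nM in this assay, which is the highest of the three numbers; how its core differs from that of compound 2 is not broken down here.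

Compound 4, `COc1ccc(-c2nc3cc(C(F)(F)F)ccc3[nH]2)c(N)c1`, is not yet measured. It differs from compound 3 by amino in place of nitro on an aromatic carbon. The place is not the same as in the earlier pair: there the amino stood para to a large group, here it stands ortho to a large group and meta to a methoxy group, so this is the same kind of change, not the same change.

Because no change at the digits printed from compound 2 to compound 1 (within the scatter), the step of no change at the digits printed from compound 3 to compound 4 (within the scatter) is expected to be about as small in this assay. Compound 4 is therefore estimated at 85000 nM, expected to fall between 35000 nM and 200000 nM.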

Compound 4, half-maximal cytotoxic concentration: 5000 nM
Compound 4: the middle estimate sits 17-fold (1.23 log units) above what was measured; the whole stated range lies above it.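

In this assay the swap of nitro for amino on an aromatic carbon does not keep its size from one core to the other: the same change on two cores in this assay, no change at the digits printed (within the scatter) from compound 2 to compound 1 and a 17-fold lower number (1.23 log units; beyond the scatter) from compound 3 to compound 4, 17-fold (1.23 log units) apart, beyond the scatter of two such steps. On the core of compound 3 the change gives a 17-fold lower number from compound 3 to compound 4 (1.23 log units; beyond the scatter) in a place ortho to a large group and meta to a methoxy group, so the near absence of a step on the core of compound 1 cannot be taken as a guide for this swap across the series. These two pairs do not show whether the gap goes with the place of the amino, with the methoxy group, or with the other substituents of the core, and two pairs make no rule.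

The compounds shown leave open how the same swap behaves with the place held fixed on either core. They also leave open how an acetamide or a carboxylic acid standing where the amino stands would read in this assay.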